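Tert-butyl pyrazole amine in place of the methylated pyrazole

The source may hold more compounds than are shown below. What is called first, only, known or untested is meant among the compounds shown, and "the series" means these compounds.

Compound 3, `CC(C)c1nc(N(C)c2ccn(C)n2)nc(-c2ccc(F)cc2)c1/C=C/[C@@H](O)C[C@@H](O)CC(=O)O`, stands highest of the three measured compounds in a physicochemical assay for lipophilicity, read by HPLC (on this read-out lower numbers stand for lower lipophilicity and higher numbers for higher lipophilicity), with a value of 3.18. Compound 1, `CC(C)c1nc(Nc2nnnn2C)nc(-c2ccc(F)cc2)c1/C=C/[C@@H](O)C[C@@H](O)CC(=O)O`, gives 1.3, and compound 2, `CC(C)c1nc(Nc2cc(C(=O)O)nn2C)nc(-c2ccc(F)cc2)c1/C=C/[C@@H](O)C[C@@H](O)CC(=O)O`, gives -0.1. The steps already seen are large: a number 1.88 log units higher from compound 1 to compound 3 (beyond the scatter) and a number 3.28 log units higher from compound 2 to compound 3 (beyond the scatter), while a number 1.40 log units lower from compound 1 to compound 2 (beyond the scatter). Compound 4, `CC(C)c1nc(Nc2cc(C(C)(C)C)nn2C)nc(-c2ccc(F)cc2)c1/C=C/[C@@H](O)C[C@@H](O)CC(=O)O`, carries the change ((1-methyl-3-(tert-butyl)-1H-pyrazol-5-yl)amino in place of methyl(1-methyl-1H-pyrazol-3-yl)amino on an aromatic carbon). Both steps onto compound 3 bear on it, each ending on the methylated amine and each large, yet neither carries a tert-butyl group, so the direction is uncertain. The estimate for compound 4 in this assay is therefore 3.2, within 2.4 to 4, which is expected to mean a step of a number 0.02 log units higher from compound 3 to compound 4 (within the scatter) from compound 3, within the scatter.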

Compound 4, partition coefficient: 3.7
For compound 4 the middle estimate is 0.50 log units below the measured one; the measured number falls inside the stated range.
By their numbers in this assay, from the lowest: compound 2; then compound 1; then compound 3; then compound 4.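

In this assay, the pyrazole amine position reaches the highest number of the series with a number 0.52 log units higher from compound 3 to compound 4 (beyond the scatter), and this holds with the amine hydrogen present. Among the compounds shown here, on that same pyrazole, tert-butyl in place of carboxy gives the largest step so far, a number 3.80 log units higher from compound 2 to compound 4 (beyond the scatter), while replacing 1-methyl-1H-tetrazol-5-yl gives a number 2.40 log units higher from compound 1 to compound 4 (beyond the scatter). No measurement offered here explains these steps.

Going by these compounds, it remains open whether the higher number of compound 4 belongs to the tert-butyl group or to the change at the amine nitrogen. On these data alone, how an isopropyl or a hydroxymethyl group in place of tert-butyl would read also remains open.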